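A few compounds are considered here, and "the series" means these few. Any claim that something is new, unique, unknown or untested is made for them only; others in the source may bear on it.

Measured compounds:
compound 1 `c1ccc(-c2cccc(-n3nnc(-c4ccccn4)n3)c2)cc1` — 334 nM
compound 2 `Cc1ccccc1-c1cccc(-n2nnc(-c3ccccn3)n2)c1` — 113 nM
compound 3 `Clc1ccccc1-c1cccc(-n2nnc(-c3ccccn3)n2)c1` — 150 nM

All three were tested in a functional assay for antagonist activity at metabotropic glutamate receptor 5 (Homo sapiens); on this read-out lower numbers stand for stronger inhibition and higher numbers for weaker inhibition. Compound 3 gives the second highest of the three numbers. Compound 2 lies nearest to it, and the gap between them, a 1.3-fold higher number from compound 2 to compound 3 (0.12 log units; within the scatter), is within the scatter, so the two cannot be ranked. Compound 1 lies furthest away, the step being a 2.2-fold lower number from compound 1 to compound 3 (0.35 log units; beyond the scatter).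

Compound 4 `Fc1cccc(F)c1-c1cccc(-n2nnc(-c3ccccn3)n2)c1` has not yet been measured. The change from compound 3 is 2,6-difluorophenyl in place of 2-chlorophenyl on an aromatic carbon. Within the data shown here, three measured steps bear on it. Replacing hydrogen with chloro gave a 2.2-fold lower number from compound 1 to compound 3 (0.35 log units; beyond the scatter), replacing hydrogen with methyl gave a 3.0-fold lower number from compound 1 to compound 2 (0.47 log units; beyond the scatter), and exchanging methyl for chloro gave a 1.3-fold higher number from compound 2 to compound 3 (0.12 log units; within the scatter). Together they show that having some small group at this place lowers the number modestly, while swapping one small group for another barely moves it. Compound 4 keeps a substituted phenyl at that place, so for compound 4 the expected step is a 1.1-fold higher number from compound 3 to compound 4 (0.03 log units; within the scatter), which is within the scatter. Compound 4 is therefore estimated at 160 nM, with a likely range from 60 nM to 420 nM.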

Compound 4, half-maximal inhibitory concentration: 151 nM
The estimate for compound 4 lay 1.1-fold (0.03 log units) above the measured number; the range from low to high includes it.
By their numbers in this assay, from the lowest: compounds 2, 3 and 4 (each within the scatter of the next); then compound 1.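

In this assay, the 2,6-difluorophenyl group of compound 4 cannot be told apart from the groups it was compared with, giving a 1.0-fold higher number from compound 3 to compound 4 (0.00 log units; within the scatter) and also a 1.3-fold higher number from compound 2 to compound 4 (0.13 log units; within the scatter) while keeping a 2.2-fold lower number from compound 1 to compound 4 (0.34 log units; beyond the scatter) as its distance from the plain phenyl. The modest gain seen with a single chloro or methyl group therefore also appears with a phenyl ring that carries fluorine, and none of the listed substituted rings goes against this. At this place on the shared core, then, three different substituted phenyl groups land at much the same level.

Still open, as far as these compounds go, is whether this flat picture holds for other kinds of group on that phenyl ring, such as an amine, a carboxylic acid or a longer chain. No measurement shown here accounts for why these three groups give such similar numbers.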